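The compounds below may be only part of what the source reports. "The series", "measured", "known", "first", "only" and "open" are said of these compounds alone.

In a functional assay on MDA-MB-231 cells (Homo sapiens) for inhibition, read by MTT assay, with a stated time of 48 h (a higher number here means a weaker inhibitor, a lower number a stronger inhibitor), compound 1 `CCc1ccc(-c2nc3ccccn3c2Sc2ccccc2)cc1` gives > 100000 nM, which is a limit and not a number. Compound 2 `Cc1ccc(-c2nc3ccccn3c2Sc2ccccc2)cc1` gives > 100000 nM, also a limit. Compound 3 `COc1ccc(-c2nc3ccccn3c2Sc2ccccc2)cc1` gives > 100000 nM, again a limit. Compound 3 therefore has no exact value and stands at the limit of > 100000 nM in this assay, at which 3 of the 3 values shown sit.

Compound 4 `N#Cc1ccc(-c2nc3ccccn3c2Sc2ccccc2)cc1` has cyano in place of methoxy on an aromatic carbon, so 4-methoxyphenyl becomes 4-cyanophenyl: cyano in place of methoxy on an aromatic carbon.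

The closest measured changes also replace one group with another on an aromatic carbon: a step that the two limits leave unreadable from compound 1 to compound 3 and a step that the two limits leave unreadable from compound 2 to compound 3. Neither gives a size or direction to carry over to the new change. The expected change is therefore none beyond the scatter, and compound 4 is expected to report the same limit in this assay.

The estimated step is a number no higher from compound 3 to compound 4 (the limit leaves the size open).

Should a number appear, compound 4 is estimated at 100000 nM, with an expected range from 30000 nM to 200000 nM.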

Compound 4, half-maximal inhibitory concentration: 17800 nM
Beside the measured number, compound 4's estimate is 5.6-fold (0.75 log units) above it; measured number below the stated range.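

In this assay, cyano in place of methoxy on an aromatic carbon, para to a large group, gives an at least 5.6-fold lower number from compound 3 to compound 4 (0.74 log units; beyond the scatter). Cyano in place of methyl gives an at least 5.6-fold lower number from compound 2 to compound 4 (0.74 log units; beyond the scatter), and cyano in place of ethyl gives an at least 5.6-fold lower number from compound 1 to compound 4 (0.74 log units; beyond the scatter), so the group at this place can bring the number down from the limit, which the three earlier compounds could not show. Compound 4 is the only compound shown with an exact value: the limit of > 100000 nM in this assay, at which 3 of the 4 values shown sit.

The steps among compound 1, compound 2 and compound 3 cannot be read, and each step to compound 4 gives only a smallest size, not a true one. On these data alone, what an amine, a carboxylic acid or a trifluoromethyl group would do at this place remains open.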